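Swapping dimethylamino for cyclopropylamino

The compounds below may be only part of what the source reports. "The series", "measured", "known", "first", "only" and "open" are said of these compounds alone.

Measured in a functional assay on HCT-15 cells (Homo sapiens) for inhibition, read by MTT assay, with a stated time of 72 h; a lower number here means a stronger inhibitor, a higher number a weaker inhibitor:
Compound 1 `COc1cc(Oc2cccc(Nc3ccccc3)c2)cc(OC)c1CNCc1ccc(F)cc1`: 3640 nM
Compound 2 `COc1cc(Oc2cccc(Nc3ccccc3)c2)cc(OC)c1CNCc1ccc(C)cc1`: 5400 nM
Compound 3 `COc1cc(Oc2cccc(Nc3ccccc3)c2)cc(OC)c1CN(C)C`: 15600 nM

Compound 3 has the highest number of the three, so it is the weakest inhibitor here. Compound 4 `COc1cc(Oc2cccc(Nc3ccccc3)c2)cc(OC)c1CNC1CC1` has cyclopropylamino in place of dimethylamino on a saturated chain carbon bound to an aromatic carbon. Among the measured compounds shown here, no measured compound carries this group, so the evidence is indirect. Two modest steps bear on it: a 4.3-fold higher number from compound 1 to compound 3 (0.63 log units; beyond the scatter) and a 2.9-fold higher number from compound 2 to compound 3 (0.46 log units; beyond the scatter). Both end at dimethylamino and start from an amino group carrying a ring. Read in reverse, the smaller one, a 2.9-fold higher number from compound 2 to compound 3 (0.46 log units; beyond the scatter), points to a small step toward a lower number in this assay, and that is what is expected here: a 1.8-fold lower number from compound 3 to compound 4 (0.26 log units; within the scatter). The estimated value for compound 4 is 8500 nM, with an expected range of 4000 nM to 18000 nM.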

Compound 4, half-maximal inhibitory concentration: 6140 nM
Estimate against measurement, compound 4: 1.4-fold (0.14 log units) above; the range from low to high includes it.
By their numbers in this assay, from the lowest: compounds 1, 2 and 4 (each within the scatter of the next); then compound 3.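

In this assay, a benzyl group on the amine nitrogen is not needed to improve on dimethylamino: cyclopropylamino gives a 2.5-fold lower number from compound 3 to compound 4 (0.40 log units; beyond the scatter) and stays within the scatter of both benzyl compounds, with a 1.1-fold higher number from compound 2 to compound 4 (0.06 log units; within the scatter) and a 1.7-fold higher number from compound 1 to compound 4 (0.23 log units; within the scatter). At this position, 4-methylbenzyl, 4-fluorobenzyl and cyclopropyl therefore cannot be told apart. No measured evidence explains the step.

Compounds 1, 2 and 4 all carry both a ring and the amine hydrogen, so the two cannot be separated. An open-chain isopropylamino or a simple methylamino group would test the ring and the hydrogen apart.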